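From Phenyl to Phenoxymethyl: What to Expect of Compound 3

The source may hold more compounds than are shown below. What is called first, only, known or untested is meant among the compounds shown, and "the series" means these compounds.

Of the compounds shown here, two sharing one core have been measured so far. Compound 1 `O=C(Nc1nnc(-c2ccc(O)c(O)c2)s1)C1CCCCC1` gives 8800 nM in a functional assay on HL-60 cells (Homo sapiens) for cytotoxicity, read by MTT assay, with a stated time of 72 h; on this read-out lower numbers stand for stronger inhibition and higher numbers for weaker inhibition. Among the measured compounds shown here, compound 2 `O=C(Nc1nnc(-c2ccc(O)c(O)c2)s1)c1ccccc1` gives 17600 nM in this assay, and the only step known, a 2.0-fold higher number from compound 1 to compound 2 (0.30 log units; within the scatter), lies within the usual scatter. Compound 3 `O=C(COc1ccccc1)Nc1nnc(-c2ccc(O)c(O)c2)s1` carries phenoxymethyl in place of phenyl on a carbonyl carbon. For the measured compounds named here, no measured step tests this exact exchange; the single step recorded, a 2.0-fold higher number from compound 1 to compound 2 (0.30 log units; within the scatter), shows that swapping the group on this carbonyl carbon left the numbers within scatter. Compound 3 is therefore expected to stay close, with an estimated step of a 1.2-fold lower number from compound 2 to compound 3 (0.07 log units; within the scatter). The estimate for compound 3 is 15000 nM, ranging from 5000 nM to 45000 nM.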

Compound 3, half-maximal inhibitory concentration: 17400 nM
Beside the measured number, compound 3's estimate is 1.2-fold (0.06 log units) below it, within the range that was stated.
By their numbers in this assay, from the lowest: compounds 1, 3 and 2 (each within the scatter of the next).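

Putting phenoxymethyl, with its one hydrogen-bond acceptor, in place of phenyl on this carbonyl carbon gives a 1.0-fold lower number from compound 2 to compound 3 (0.00 log units; within the scatter) in this assay, and putting it in place of cyclohexyl gives a 2.0-fold higher number from compound 1 to compound 3 (0.30 log units; within the scatter) in the same assay. Cyclohexyl, phenyl and phenoxymethyl therefore cannot be told apart here, even with the added oxygen atom in the new group. No supporting data are available to explain this result. Still open, going by these compounds, is whether an amine or a carboxylic acid at this place would produce a step beyond the scatter. A longer chain carrying the same phenyl ring also remains untested among the compounds shown.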